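Cinnamamide extension of an iminosugar: a bromo to methoxy swap

A few compounds are considered here, and "the series" means these few. Any claim that something is new, unique, unknown or untested is made for them only; others in the source may bear on it.

Measured so far:
compound 1 `NC[C@@H]1NC[C@H](O)[C@H](O)[C@H]1O` gives 13%
compound 2 `COc1ccc(Br)cc1/C=C/C(=O)NC[C@H]1NC[C@H](O)[C@@H](O)[C@H]1O` gives 47%

In an assay on isolated protein for inhibition of alpha-galactosidase (Coffea arabica), read by spectrophotometry, tested at 100 uM (on this read-out higher numbers stand for more inhibition at the one concentration tested (going by the name of the read-out) and lower numbers for less inhibition), compound 1, the unsubstituted iminosugar, gives 13%. Within the data shown here, compound 2, which carries a cinnamamide on the exocyclic amine of the same core, gives 47% in this assay and thus stands highest of the two numbers known, with the gap to compound 1 lying beyond the usual scatter. Among the measured compounds shown here, the two values show that the amide extension goes with stronger inhibition, but no step between measured compounds is available to weigh any single change on the aromatic ring.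

Compound 3 `COc1ccc(OC)c(/C=C/C(=O)NC[C@H]2NC[C@H](O)[C@@H](O)[C@H]2O)c1` is the next compound to be measured in this assay. Its difference from compound 2 is methoxy in place of bromo on an aromatic carbon.

Since nothing measured speaks to this change, the expectation is a step from compound 2 to compound 3 of a number 7 percentage points lower from compound 2 to compound 3 (within the scatter), that is, none beyond the scatter or a small loss. For compound 3 the estimate in this assay is 40%, with a range from 25% to 58%.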

Compound 3, a percentage reported as inhibition, at one concentration (the size of the read-out at that concentration, not a potency): 57%
Compound 3: middle estimate off by 17 percentage points, on the low side; the measured number falls inside the stated range.
By their numbers in this assay, from the lowest: compound 1; then compounds 2 and 3 (each within the scatter of the next).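

In this assay, the aromatic carbon meta to a large group and para to a methoxy group accepts methoxy in place of bromo with a step of a number 10 percentage points higher from compound 2 to compound 3 (within the scatter), so compound 2 and compound 3 cannot be told apart on this read-out. Bromine is therefore not needed at this position to keep the inhibition seen for compound 2, and the hydrogen-bond acceptor that enters with the methoxy group leaves the number within the scatter. No measurement on hand explains why the two groups read alike.

Among these compounds, the single swap compares only two groups at one position, so it remains open whether this position responds to substitution at all, and an amine, a carboxylic acid or a longer alkoxy chain there would test this more widely than bromo and methoxy do. The contribution of the other methoxy group, shared by compound 2 and compound 3, also stays open, as no step among the compounds shown changes it.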